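A few compounds are considered here, and "the series" means these few. Any claim that something is new, unique, unknown or untested is made for them only; others in the source may bear on it.

Working notes on the series. Compound 1 `CN1OC(n2cc3ccoc3nc2=O)CC1CO` carries the shared core with no aryl group attached. In an ADME assay on MRC5 cells (Homo sapiens) for cytotoxicity, read by microscopy, with a stated time of 96 h (a higher number here means that more compound is tolerated, a lower number that less compound is tolerated), compound 1 gives only a limit, > 250000 nM. Within the data shown here, compound 2 `CCCCCc1ccc(-c2cc3cn(C4CC(CO)N(C)O4)c(=O)nc3o2)cc1` adds a pentyl-substituted phenyl ring; in this assay compound 2 gives 6000 nM, the one actual number in the set. The other value, that of compound 1, is a limit (the limit of > 250000 nM in this assay, at which 1 of the 2 values shown sits). Compound 3 `COc1ccc(-c2cc3cn(C4CC(CO)N(C)O4)c(=O)nc3o2)cc1` differs from compound 2 by methoxy in place of pentyl on an aromatic carbon. Among the measured compounds shown here, no measured step between two compounds exists here; the move from compound 2 to compound 3 is expected to lift tolerance beyond the scatter, a 5.0-fold higher number from compound 2 to compound 3 (0.70 log units; beyond the scatter). Compound 3 is estimated at 30000 nM, within 8000 nM to 200000 nM.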

Compound 3, minimum cytotoxic concentration: 62000 nM
Estimate against measurement, compound 3: 2.1-fold (0.32 log units) below; low and high end bracket the measured number.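

In this assay, the group on this aromatic carbon, para to a large group, clearly moves the read-out: methoxy in place of pentyl gives a 10-fold higher number from compound 2 to compound 3 (1.01 log units; beyond the scatter). The 4-methoxyphenyl group in place of hydrogen still gives an at least 4.0-fold lower number from compound 1 to compound 3 (0.60 log units; beyond the scatter), so tolerance with methoxy remains separated from that of the bare core. That second step rests on a limit for compound 1: the limit of > 250000 nM in this assay, at which 1 of the 3 values shown sits.

Open, on these data alone, is whether the read-out follows chain length, as an ethyl or butyl group here would show. Also open, as far as these compounds go, is how an amine or a carboxylic acid at this carbon would read.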